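The compounds below may be only part of what the source reports. "The series", "measured", "known", "first", "only" and "open" are said of these compounds alone.

In a functional assay on HT-29 cells (Homo sapiens) (on this read-out lower numbers stand for an effect already at smaller amounts and higher numbers for an effect only at larger amounts of compound), compound 2 `NC(=O)Nc1sc(-c2ccc(C(=O)N3CCOCC3)cc2)cc1C(=O)N[C@H]1CCCNC1` gives 610 nM, the lower of the two numbers available. Compound 1 `CS(=O)(=O)Nc1ccc(-c2cc(C(=O)N[C@H]3CCCNC3)c(NC(N)=O)s2)cc1` gives 2200 nM. For compound 3 `NC(=O)Nc1sc(-c2ccccc2)cc1C(=O)NC1CCNCC1` the entry reads "not determined" (no result reported), so it offers no comparison.

The next compound is compound 4 `NC(=O)Nc1sc(-c2ccc(N)cc2)cc1C(=O)N[C@H]1CCCNC1`. The change is amino in place of (morpholin-4-yl)carbonyl on an aromatic carbon. Among the compounds with values here, only one measured step involves a change at this aromatic carbon: a 3.6-fold lower number from compound 1 to compound 2 (0.56 log units; beyond the scatter), which is modest and beyond the scatter. Within the data shown here, no measured compound carries amino there, so the direction of the change is poorly supported.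

Among the measured compounds shown here, compound 2 holds the lower number of the measured pair at 610 nM, so removing its (morpholin-4-yl)carbonyl is expected to raise the number in this assay, by a modest amount no larger than the one measured step. The estimated change is a 1.8-fold higher number from compound 2 to compound 4 (0.26 log units; within the scatter). For compound 4 the estimated value is 1100 nM, with an expected range of 350 nM to 3500 nM.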

Compound 4, half-maximal effective concentration: 920 nM
Compound 4: middle estimate off by 1.2-fold (0.08 log units), on the high side; the range from low to high includes it.
By their numbers in this assay, from the lowest: compounds 2 and 4 (each within the scatter of the next); then compound 1.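

At this aromatic carbon, para to a large group, amino in place of (morpholin-4-yl)carbonyl gives a 1.5-fold higher number from compound 2 to compound 4 (0.18 log units; within the scatter) in this assay and so does not separate the two groups, even though one brings a ring and the other is a single nitrogen. Hydrogen in place of methylsulfonyl on the nitrogen gives a 2.4-fold lower number from compound 1 to compound 4 (0.38 log units; beyond the scatter) and, with the earlier step of a 3.6-fold lower number from compound 1 to compound 2 (0.56 log units; beyond the scatter), sets compound 1 apart from both compound 2 and compound 4 in this series. No measurement at hand explains either step.

The compounds shown leave open how a carboxylic acid or a dimethylamino group would read at this carbon. On these data alone, whether a longer chain on the amino nitrogen stays level with compound 4 or moves towards compound 1 also remains open.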